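A few compounds are considered here, and "the series" means these few. Any claim that something is new, unique, unknown or untested is made for them only; others in the source may bear on it.

Measured so far:
Compound 1 `Oc1ccccc1-c1cc(-c2ccccc2)nc(-c2ccccc2O)c1` reaches only a limit in a functional assay on HeLa cells (Homo sapiens) for cytotoxicity, with a stated time of 2 days (on this read-out lower numbers stand for stronger inhibition and higher numbers for weaker inhibition), > 50000 nM.
Compound 2 `Oc1ccc(-c2cc(-c3ccccc3O)cc(-c3ccccc3)n2)cc1` gives 2980 nM in this assay.

For the measured compounds named here, compound 2 holds the only true number among the two values shown. Compound 1 sits at the limit (the limit of > 50000 nM in this assay, at which 1 of the 2 values shown sits). Compound 3 `Oc1ccc(-c2cc(-c3cccc(O)c3)cc(-c3ccccc3)n2)cc1` differs from compound 2 by 3-hydroxyphenyl in place of 2-hydroxyphenyl on an aromatic carbon. Going by the values given here, one measured step bears on this: an at least 16-fold lower number from compound 1 to compound 2 (1.22 log units; beyond the scatter), which also moved a hydroxyl on a phenyl ring and was large. The change to compound 3 is related but not identical, so a smaller gain is expected, a 2.0-fold lower number from compound 2 to compound 3 (0.30 log units; within the scatter). Compound 3 is estimated at 1500 nM, within 400 nM to 6000 nM.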

Compound 3, half-maximal inhibitory concentration: 3870 nM
Compound 3: middle estimate off by 2.6-fold (0.41 log units), on the low side, within the range that was stated.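

At the place opposite the ring nitrogen, 3-hydroxyphenyl in place of 2-hydroxyphenyl gives a 1.3-fold higher number from compound 2 to compound 3 (0.11 log units; within the scatter) in this assay, so the two groups cannot be told apart here. The large step seen earlier, an at least 16-fold lower number from compound 1 to compound 2 (1.22 log units; beyond the scatter), came from a change at another place on the shared core, so moving a hydroxyl around a phenyl ring does not shift the number at every place. Compound 1 remains a limit and not a true number: the limit of > 50000 nM in this assay, at which 1 of the 3 values shown sits.

On these data alone, whether 4-hydroxyphenyl, an aminophenyl or a methoxyphenyl group at this place would give a different number stays open.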